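Series notes: 2,4-dimethoxyphenyl to 3,4-dimethoxyphenyl

The compounds below may be only part of what the source reports. "The series", "measured", "known", "first", "only" and "open" are said of these compounds alone.

In a functional assay on MCF7 cells (Homo sapiens) for inhibition, read by MTT assay, with a stated time of 48 h (a higher number here means a weaker inhibitor, a lower number a stronger inhibitor), compound 1 (`Oc1cccc(C(c2c[nH]c3ccc(Br)cc23)c2c[nH]c3ccc(Br)cc23)c1`) gives 2800 nM, and compound 2 (`COc1ccc(C(c2c[nH]c3ccc(Br)cc23)c2c[nH]c3ccc(Br)cc23)c(OC)c1`) gives 77500 nM. Compound 2 therefore holds the higher number of the pair and is the weaker inhibitor. Among the compounds with values here, the single measured step, a 28-fold higher number from compound 1 to compound 2 (1.44 log units; beyond the scatter), is large and puts 2,4-dimethoxyphenyl in place of 3-hydroxyphenyl. Compound 3 (`COc1ccc(C(c2c[nH]c3ccc(Br)cc23)c2c[nH]c3ccc(Br)cc23)cc1OC`) has the same atoms as compound 2, joined differently: 3,4-dimethoxyphenyl in place of 2,4-dimethoxyphenyl on a saturated chain carbon bound to two aromatic carbons. Within the data shown here, the measured step bears on this change only indirectly, since no measured pair compares the two dimethoxyphenyl groups. With compound 2 at the top of the measured numbers, a moderate move toward compound 1 is the working expectation. In this assay the expected change is a 2.6-fold lower number from compound 2 to compound 3 (0.41 log units; beyond the scatter). The estimate for compound 3 is 30000 nM, with an expected range of 7000 nM to 100000 nM.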

Compound 3, half-maximal inhibitory concentration: 7800 nM
Estimate against measurement, compound 3: 3.8-fold (0.59 log units) above, and the stated range covers the measured number.
By their numbers in this assay, from the lowest: compound 1; then compound 3; then compound 2.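

In this assay, rearranging the same atoms is enough to produce a clear change at this place on the saturated chain carbon bound to two aromatic carbons: a 9.9-fold lower number from compound 2 to compound 3 (1.00 log units; beyond the scatter). Compound 2 and compound 3 both carry two methoxy groups in place of a hydroxyl, and the large loss is seen in full only with compound 2. The gap to the hydroxyl-bearing compound narrows to a 2.8-fold higher number from compound 1 to compound 3 (0.44 log units; beyond the scatter). Nothing available here accounts for the difference between the two dimethoxyphenyl groups.

The shown compounds do not separate the effect of removing the hydroxyl from that of adding a second substituent to the ring. As far as these compounds go, it also remains open how a phenyl group carrying a single methoxy group, an amine or a carboxylic acid would read at this place.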